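Swapping 4-nitrophenyl for 3-hydroxyphenyl on the shared core

This account rests on a few compounds, and the source may have more. Where it says the series, first, only, none or still open, it means among the compounds named here.

- Compound 1 `COc1cc(-n2cnc3ccc(-c4ccccc4Cl)cc32)cc(OC)c1OC`: > 10000 nM
- Compound 2 `COc1cc(-n2cnc3ccc(-c4ccc(C(C)=O)cc4)cc32)cc(OC)c1OC`: 450 nM
- Compound 3 `COc1cc(-n2cnc3ccc(-c4ccc([N+](=O)[O-])cc4)cc32)cc(OC)c1OC`: 79 nM

All three were tested in a functional assay on SGC-7901 cells (Homo sapiens) for antiproliferative activity, read by MTT assay, with a stated time of 72 h; on this read-out higher numbers stand for weaker inhibition and lower numbers for stronger inhibition. The entry for compound 1 is a limit of the assay and not a number. Of the two true numbers, compound 3 holds the lower, with 79 nM, and its steps to both other compounds lie beyond the scatter.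

The next compound is compound 4 `COc1cc(-n2cnc3ccc(-c4cccc(O)c4)cc32)cc(OC)c1OC`, with 3-hydroxyphenyl in place of 4-nitrophenyl on an aromatic carbon.

Three measured steps changed this same aromatic group. Two were large, an at least 22-fold lower number from compound 1 to compound 2 (1.34 log units; beyond the scatter) and an at least 120-fold lower number from compound 1 to compound 3 (2.10 log units; beyond the scatter), and one was modest, a 5.7-fold lower number from compound 2 to compound 3 (0.76 log units; beyond the scatter). Among the measured compounds shown here, only compound 3 and compound 2 share the 4-position, and none of the measured compounds carries a hydroxyl group, so these steps show how far the number can move and not exactly where it will land. Since compound 3 is already the lowest, a move toward weaker inhibition seems more likely than a further gain.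

The expected change is an 8.9-fold higher number from compound 3 to compound 4 (0.95 log units; beyond the scatter), a modest to large step.

For compound 4, the estimate is 700 nM, with an expected range of 120 nM to 5000 nM.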

Compound 4, half-maximal inhibitory concentration: 53 nM
Estimate against measurement, compound 4: 13-fold (1.12 log units) above, and the stated range ends above it.
By their numbers in this assay, from the lowest: compounds 4 and 3 (each within the scatter of the next); then compound 2. At a limit, above all of these: compound 1.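

In this assay, replacing 4-nitrophenyl with 3-hydroxyphenyl gives no change that can be told from the scatter: a 1.5-fold lower number from compound 3 to compound 4 (0.17 log units; within the scatter). A low number at this position therefore does not depend on 4-nitrophenyl, and 3-hydroxyphenyl, which carries a hydrogen-bond donor that the other three groups lack, stands clearly apart from the other two groups, with an 8.5-fold lower number from compound 2 to compound 4 (0.93 log units; beyond the scatter) and an at least 180-fold lower number from compound 1 to compound 4 (2.27 log units; beyond the scatter). The entry for compound 1 is a limit of the assay and not a number: the limit of > 10000 nM in this assay, at which 1 of the 4 values shown sits.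

The compounds shown leave open how 4-hydroxyphenyl, 3-aminophenyl or an unsubstituted phenyl ring would read. Compound 4 alone carries a hydroxyl group, so the effect of that group cannot yet be separated from the effect of where it sits on the ring.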